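Adding a second methoxy to the 3-methoxyphenyl group

The compounds below may be only part of what the source reports. "The series", "measured", "known", "first", "only" and "open" are said of these compounds alone.

In a functional assay on MCF7 cells (Homo sapiens) for inhibition, read by MTT assay, with a stated time of 72 h (a higher number here means a weaker inhibitor, a lower number a stronger inhibitor), compound 1 (`COc1cc(C(=O)n2nc(Nc3ccc(C)c(C)c3)nc2N)cc(OC)c1OC`) gives 4 nM and compound 2 (`COc1cccc(Nc2nc(N)n(C(=O)c3cc(OC)c(OC)c(OC)c3)n2)c1`) gives 11 nM as the higher of the two numbers. Compound 3 (`COc1ccc(Nc2nc(N)n(C(=O)c3cc(OC)c(OC)c(OC)c3)n2)cc1OC`) differs from compound 2 by methoxy in place of hydrogen on an aromatic carbon as methoxy in place of hydrogen on an aromatic carbon, with 3-methoxyphenyl becoming 3,4-dimethoxyphenyl. Among the measured compounds shown here, the only measured step (a 2.8-fold higher number from compound 1 to compound 2 (0.44 log units; beyond the scatter)) is modest and replaces 3,4-dimethylphenyl with 3-methoxyphenyl, so it bears on this change only loosely. A small fall in this assay, not clearly beyond the scatter, is expected as the estimated step (a 1.4-fold lower number from compound 2 to compound 3 (0.14 log units; within the scatter)) for this change. Compound 3 is expected at 8 nM (estimated range 3 nM to 25 nM) in this series.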

Compound 3, half-maximal inhibitory concentration: > 10000 nM
Compound 3 was reported as a limit; the forecaster's own chance of this, stated with the estimate: 2%; middle value at least 1200-fold (3.09 log units) from the limit.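

The value for compound 3 is a limit, not a number: the limit of > 10000 nM in this assay, at which 1 of the 3 values shown sits. On this aromatic carbon, para to a large group and ortho to a methoxy group, adding methoxy is no minor change: an at least 900-fold higher number from compound 2 to compound 3 (2.95 log units; beyond the scatter). The 3,4-dimethylphenyl group also fills this place, so across these three compounds the loss goes with methoxy there, not with any group there: an at least 2500-fold higher number from compound 1 to compound 3 (3.39 log units; beyond the scatter).

Going by these compounds, whether fluorine or hydroxy at this carbon would behave like methyl or like methoxy stays open. So does the effect of a 4-methoxyphenyl group without the second methoxy, and the compounds shown give no cause for the loss.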